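Bromo to trifluoromethyl on the phenoxy ring of compound 2

This account rests on a few compounds, and the source may have more. Where it says the series, first, only, none or still open, it means among the compounds named here.

Compound 1 `Cc1nn(C)c(Oc2ccc(F)cc2F)c1/C=N\CCCCCCOc1cc2oc(=O)cc(C)c2cc1Cl` was tested in a functional assay on SMMC-7721 cells (Homo sapiens) for antiproliferative activity, read by MTT assay, with a stated time of 72 h (a lower number here means a stronger inhibitor, a higher number a weaker inhibitor), and gives only a limit, > 25000 nM, which is one of the two values shown (the limit of > 25000 nM in this assay, at which 1 of the 2 values shown sits). Compound 2 `Cc1nn(C)c(Oc2cccc(Br)c2)c1/C=N\CCCCCCOc1cc2oc(=O)cc(C)c2cc1Cl` gives 5080 nM in this assay. Within the data shown here, the step of an at least 4.9-fold lower number from compound 1 to compound 2 (0.69 log units; beyond the scatter) is the only measured step in the set. Among the measured compounds shown here, compound 2 therefore stands as the one compound with a number in this assay; the other value is a limit.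

Compound 3 `Cc1nn(C)c(Oc2cccc(C(F)(F)F)c2)c1/C=N\CCCCCCOc1cc2oc(=O)cc(C)c2cc1Cl` differs from compound 2 by trifluoromethyl in place of bromo on an aromatic carbon. For the measured compounds named here, the single measured step also changes the substituent pattern on the same phenoxy ring, but it swaps a different pair of groups and starts from a limit, so it only shows that this ring tolerates a change of this kind with a modest shift. Going by the values given here, no measured step exchanges bromo for trifluoromethyl.

Compound 3 is thus expected to stay near compound 2, with a step of a 1.1-fold higher number from compound 2 to compound 3 (0.03 log units; within the scatter) that is within the scatter. The estimate for compound 3 in this assay is 5500 nM, with a range from 2000 nM to 16000 nM.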

Compound 3, half-maximal inhibitory concentration: 24800 nM
The estimate for compound 3 lay 4.5-fold (0.65 log units) below the measured number; the whole stated range lies below it.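

In this assay, the place on the phenoxy ring meta to a large group responds to the identity of the group alone: trifluoromethyl in place of bromo gives a 4.9-fold higher number from compound 2 to compound 3 (0.69 log units; beyond the scatter). The earlier step changed both the groups and their pattern on the ring, whereas this one keeps the place fixed, so the shift belongs to this single exchange. Bromo and trifluoromethyl both count 0 hydrogen-bond donors, 0 hydrogen-bond acceptors and no net charge, so a change in those counts plays no part in this step, and of this pair compound 2 gives the lower number.

The size of the step of a number no higher from compound 1 to compound 3 (the limit leaves the size open) cannot be read. Compound 1 gives only a limit: the limit of > 25000 nM in this assay, at which 1 of the 3 values shown sits.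

The compounds shown leave open whether the exchange of bromo for trifluoromethyl would give a step of similar size with a longer chain in the linker.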